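The source may hold more compounds than are shown below. What is called first, only, known or untested is meant among the compounds shown, and "the series" means these compounds.

Series notes. Compound 1 `O=C(Nc1ccc(Oc2ccc(-c3nccs3)cc2)cc1)Nc1ccc(F)c(C(F)(F)F)c1` gives 76.4% in a functional assay on A549 cells (Homo sapiens) for inhibition, read by MTT assay and WST assay, with a stated time of 72 h, tested at 10 uM; on this read-out higher numbers stand for more inhibition of growth at the one concentration tested and lower numbers for less inhibition of growth. Compound 2 `O=C(Nc1ccc(Oc2ccc(-c3nccs3)cc2)cc1)Nc1cc(Br)cc(C(F)(F)F)c1` gives 81.7% in this assay, and compound 3 `CC(=O)Oc1sccc1NC(=O)Nc1ccc(Oc2ccc(-c3nccs3)cc2)cc1` gives 6.78%. Compound 1 thus sits with compound 2 at the high end, the two indistinguishable since a number 5.3 percentage points higher from compound 1 to compound 2 (within the scatter), while a number 69.6 percentage points lower from compound 1 to compound 3 (beyond the scatter) and a number 74.9 percentage points lower from compound 2 to compound 3 (beyond the scatter) are both large. Every measured step alters the aryl group on the amide-type nitrogen; none touches the other end of the shared core. Compound 4 `O=C(Nc1ccc(Oc2ccc(-c3ncc[nH]3)cc2)cc1)Nc1ccc(F)c(C(F)(F)F)c1` differs from compound 1 at exactly that untouched end: 1H-imidazol-2-yl in place of 1,3-thiazol-2-yl on an aromatic carbon. Going by the values given here, no measured step bears on this change, so only a moderate departure from compound 1 is expected, with a wide band. The expected step is a number 11.4 percentage points lower from compound 1 to compound 4 (beyond the scatter). Compound 4 is estimated at 65%, between 35% and 85%.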

Compound 4, percent growth inhibition at one concentration: 63.3%
Compound 4: the middle estimate sits 1.7 percentage points above what was measured, within the range that was stated.
By their numbers in this assay, from the lowest: compound 3; then compound 4; then compounds 1 and 2 (each within the scatter of the next).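

Going by these compounds alone, the end of the shared core that no earlier step touched does respond in this assay: with 1H-imidazol-2-yl in place of 1,3-thiazol-2-yl there is a number 13.1 percentage points lower from compound 1 to compound 4 (beyond the scatter), a modest step beside the large ones on the amide-type nitrogen. This position therefore accepts one five-membered aromatic ring with 2 hetero atoms in place of another while much of the growth inhibition remains. No measurement at hand explains this step.

Still open, on these data alone, is how a carboxylic acid or an amine on this aromatic carbon would read. As far as these compounds go, it is also open whether 1H-imidazol-2-yl gives a similar step alongside the 3-bromo-5-(trifluoromethyl)phenyl of compound 2.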